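The source may report more compounds than this note shows. Statements on the series, on what has been measured and on what is new or still open speak of the compounds shown alone.

In an ADME assay on microsomes from liver (Homo sapiens) for metabolic stability, with a stated time of 10 min (on this read-out higher numbers stand for a more stable compound and lower numbers for a less stable compound), compound 1 `FC(F)(F)c1ccccc1-c1ccc2[nH]c(C3=NCC4(CCCCC4)N3)nc2c1` gives 97% and compound 2 `FC(F)(F)c1ccccc1-c1ccc2[nH]c(C3=NOC4(CCCCC4)C3)nc2c1` gives 100% so the two values lie within the usual scatter of each other, near the top of the scale. Going by the values given here, compound 3 `FC(F)Oc1ccccc1-c1ccc2[nH]c(C3=NOC4(CCCCC4)C3)nc2c1` is not yet measured and carries difluoromethoxy in place of trifluoromethyl on an aromatic carbon as its only change from compound 2. Among the compounds with values here, no measured pair of compounds differing in one place shows how large such a step tends to be. A slight fall, not beyond the scatter, is expected (a number 8 percentage points lower from compound 2 to compound 3 (within the scatter)). In this assay compound 3 is estimated at 92% with a range from 78% to 100% as the expected span.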

Compound 3, percent of the compound remaining: 100%
The estimate for compound 3 lay 8 percentage points below the measured number; measured number inside the range.
By their numbers in this assay, from the lowest: compounds 1, 2 and 3 (each within the scatter of the next).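

In this assay, replacing trifluoromethyl with difluoromethoxy, ortho to a large group, gives no change at the digits printed from compound 2 to compound 3 (within the scatter) in the only single-place step shown. At this position, then, the two groups cannot be told apart by this assay, and an oxygen atom linking the group to the ring is tolerated in this one pair. Nothing available explains this result. On these data alone, whether an amine or a carboxylic acid at this position would read the same stays open. So does whether this swap would behave alike on the core of compound 1.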